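A few compounds are considered here, and "the series" means these few. Any claim that something is new, unique, unknown or untested is made for them only; others in the source may bear on it.

Measured so far:
compound 1 `CCCn1c(N2CCN(C)CC2)nc2ccccc21` with 380 nM
compound 2 `CCOCCn1c(N2CCCN(Cc3ccccc3)CC2)nc2ccccc21` with 15 nM

In a functional assay on ileum for inhibition of histamine H1 receptor (Cavia porcellus) (a lower number here means a stronger inhibitor, a higher number a weaker inhibitor), compound 1 stands at the highest of the two numbers measured; its nearest neighbour, compound 2, gives 15 nM, a difference beyond the usual scatter of repeated measurements, so compound 2 is the stronger inhibitor of the two. Compound 3 `CCCC(C)Cn1c(N2CCN(C)CC2)nc2ccccc21` has not yet been measured in this assay. It differs from compound 1 in a single place: propyl in place of hydrogen on a saturated chain carbon bound to two saturated chain carbons. For the measured compounds named here, no measured pair in this set shows what such a change does, so the expectation rests on compound 1 alone, with compound 2 showing only that lower numbers are reachable. For compound 3 a modest step downward is expected, a 1.5-fold lower number from compound 1 to compound 3 (0.18 log units; within the scatter), with no strong grounds for anything beyond the scatter. Compound 3 is therefore estimated at 250 nM in this assay, in a range from 80 nM to 800 nM.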

Compound 3, half-maximal inhibitory concentration: 500 nM
Compound 3: middle estimate off by 2.0-fold (0.30 log units), on the low side; the measured number falls inside the stated range.
By their numbers in this assay, from the lowest: compound 2; then compounds 1 and 3 (each within the scatter of the next).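

In this assay, propyl in place of hydrogen on a saturated chain carbon bound to two saturated chain carbons gives a 1.3-fold higher number from compound 1 to compound 3 (0.12 log units; within the scatter), so this position takes the added propyl with no difference that can be told from the scatter. For the compounds shown here, the same change reads as propyl to 2-methylpentyl, and it is the first pair in the set to speak to this position at all. Nothing available bears on why the two numbers lie so close.

On these data alone, whether a methyl, a hydroxyl, an amine or a phenyl ring on this chain carbon would read the same way remains open, as does the outcome for a longer chain. Also open, as far as these compounds go, is whether propyl at this place would give the same reading on compound 2, which differs from compound 1 in more than one place.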